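Removing a Methyl Group from a Shared Fused Core

This account rests on a few compounds, and the source may have more. Where it says the series, first, only, none or still open, it means among the compounds named here.

Of the compounds shown here, three have been measured in a functional assay on NCI-H460 cells (Homo sapiens) for antiproliferative activity; a lower number here means a stronger inhibitor of growth, a higher number a weaker inhibitor of growth. Compound 1 `Cc1ccc2c(O)cc(-c3cccc(Cl)c3)nc2n1` gives 41.7 nM. Compound 3 `Cc1cc(C)c2c(O)cc(-c3cccc(Cl)c3)nc2n1` gives 224 nM. Compound 2 `Cc1cc(C)c2c(O)cc(-c3cccc4ccccc34)nc2n1` gives 631 nM, the highest of the three numbers, with its nearest neighbour being compound 3 and its furthest compound 1.

Compound 3 and compound 1 differ in one place only: hydrogen in place of methyl on an aromatic carbon. That single change produced a step of a 5.4-fold lower number from compound 3 to compound 1 (0.73 log units; beyond the scatter). Compound 2 and compound 3 carry the same two methyl groups on the same core, but the difference between the two cores is not broken down here; what the two numbers show is that compound 2 at 631 nM stands above compound 3 at 224 nM.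

Compound 4 `Cc1ccc2c(O)cc(-c3cccc4ccccc34)nc2n1` has not yet been measured in this assay. Going by the values given here, it arises from compound 2 by hydrogen in place of methyl on an aromatic carbon, the same change at the same place as the one already seen from compound 3 to compound 1. Among the compounds with values here, since only one measured example of this change exists, and since compound 2 differs elsewhere from compound 3, the expected step from compound 2 to compound 4 is taken as a 4.9-fold lower number from compound 2 to compound 4 (0.69 log units; beyond the scatter), resting on the earlier step of a 5.4-fold lower number from compound 3 to compound 1 (0.73 log units; beyond the scatter). Compound 4 is therefore expected to give about 130 nM in this assay, with a likely range from 50 nM to 350 nM.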

Compound 4, concentration for 50% growth inhibition: 17.4 nM
The estimate for compound 4 lay 7.5-fold (0.87 log units) above the measured number, outside the stated range (below it).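

In this assay, replacing the methyl group opposite the ring nitrogen with hydrogen again lowered the number, this time with a step of a 36-fold lower number from compound 2 to compound 4 (1.56 log units; beyond the scatter) on the core of compound 2. The direction of the change therefore held in both available pairs, but its size did not carry over from one core to the other: the same change on two cores in this assay, a 5.4-fold lower number (0.73 log units; beyond the scatter) from compound 3 to compound 1 and a 36-fold lower number (1.56 log units; beyond the scatter) from compound 2 to compound 4, 6.8-fold (0.83 log units) apart, beyond the scatter of two such steps. This shows that, in this series, a step measured on one core was a poor guide to the size of the same step on another, but it does not show why the two steps differ, and two pairs cannot establish a general rule or predict the size of the step on a third core.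

The compounds shown leave open whether a longer chain such as ethyl, or a methoxy group or a fluorine atom, would give a number closer to that of methyl or of hydrogen at this place on each core. They also leave open how the step would behave if the ring that differs between the two cores carried an amine or a carboxylic acid.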